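The source may report more compounds than this note shows. Statements on the series, on what has been measured and on what is new or still open speak of the compounds shown alone.

Working notes on the series, read in an ADME assay on microsomes from liver (Homo sapiens) for metabolic stability, read by LC-MS, using NADPH, with stated times of 5 min and 30 min, tested at 1 uM; a higher number here means that more of the compound is left, a lower number that less of the compound is left. Compound 1 (`COc1ccc(S(=O)(=O)/C=C/c2ccccn2)cc1`) gives 56%, the higher of the two numbers available. Compound 3 (`COc1ccc(S(=O)(=O)/C=C/c2ccc(Cl)cn2)cc1`) gives 6%. Compound 2 (`COc1ccc(S(=O)(=O)/C=C/c2cccc(Cl)n2)cc1`) has the entry "not determined" (no result reported), so it adds no number for comparison.

Next in line is compound 4 (`COc1ccc(S(=O)(=O)/C=C/c2ncccc2F)cc1`), which carries fluoro in place of hydrogen on an aromatic carbon relative to compound 1: fluoro in place of hydrogen on an aromatic carbon. Going by the values given here, one measured step bears on this change, chloro in place of hydrogen on an aromatic carbon, and it is large: a number 50 percentage points lower from compound 1 to compound 3 (beyond the scatter). Among the compounds with values here, it is a single example with a different entering group, and no measured step involves fluoro. A drop in this assay is still expected, though a smaller one, and this expectation rests only on compound 3 at 6%. The expected step is a number 18 percentage points lower from compound 1 to compound 4 (beyond the scatter). For compound 4 the estimate is 38%, with an expected range of 12% to 62%.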

Compound 4, percent of the compound remaining: 1.8%
The estimate for compound 4 lay 36.2 percentage points above the measured number, outside the stated range (below it).
By their numbers in this assay, from the lowest: compounds 4 and 3 (each within the scatter of the next); then compound 1.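

In this assay, fluoro on an aromatic carbon, ortho to a large group and two atoms from the ring nitrogen, gives a number 54.2 percentage points lower from compound 1 to compound 4 (beyond the scatter). Going by these compounds alone, a single fluorine atom in place of hydrogen is thus enough for a large step at this place, and a number 50 percentage points lower from compound 1 to compound 3 (beyond the scatter) is no longer the only large step: both compounds with a halogen in place of a ring hydrogen that carry a number stand beyond the scatter from compound 1. Nothing measured in the series accounts for this step.

From the compounds shown here alone, whether any group at this place would keep more of the compound remaining in this assay, for example an amine or a carboxylic acid, stays open. Compound 2 carries no number, so what chloro does at its place cannot be read.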